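Adding an Amino Group to a Nucleoside Core

A few compounds are considered here, and "the series" means these few. Any claim that something is new, unique, unknown or untested is made for them only; others in the source may bear on it.

Measured compounds:
compound 1 `COc1ncnc2c1c(-c1ccoc1)cn2[C@@H]1O[C@H](CO)[C@@H](O)[C@H]1O`: 110 nM in a functional assay on CCRF-CEM cells (Homo sapiens), read by MTT assay, with a stated time of 72 h; a lower number here means a stronger inhibitor, a higher number a weaker inhibitor
compound 2 `COc1nc(N)nc2c1c(-c1ccoc1)cn2[C@@H]1O[C@H](CO)[C@@H](O)[C@H]1O`: > 20000 nM in this assay, a limit only
compound 3 `O=c1[nH]cnc2c1c(-c1cc3ccccc3o1)cn2[C@@H]1O[C@H](CO)[C@@H](O)[C@H]1O`: > 20000 nM in this assay, a limit only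

Within the data shown here, the one counted step is amino in place of hydrogen on an aromatic carbon, and it made an at least 180-fold higher number from compound 1 to compound 2 (2.25 log units; beyond the scatter). Between compound 1 and compound 3 the difference of the two cores is not broken down here. Compound 4 `Nc1nc2c(c(-c3cc4ccccc4o3)cn2[C@@H]2O[C@H](CO)[C@@H](O)[C@H]2O)c(=O)[nH]1` carries the same kind of change as compound 2: amino in place of hydrogen on an aromatic carbon. The two places are not identical, since in compound 1 the carbon is meta to a methoxy group (2 heavy atoms) while in compound 3 it is meta to a group of 1 heavy atom. Compound 3 already sits at the limit of > 20000 nM in this assay, at which 2 of the 3 values shown sit, and compound 4 is expected to show a step that the limit leaves unreadable from compound 3 to compound 4, most likely as a limit again. For compound 4 the estimate is 40000 nM, between 15000 nM and 150000 nM.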

Compound 4, half-maximal inhibitory concentration: > 20000 nM
Compound 4 was reported as a limit; the forecaster's own chance of this, stated with the estimate: 85%; the middle value does not contradict the limit.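

No step can be read from compound 3 to compound 4, since both are reported only as limits in this assay: the limit of > 20000 nM in this assay, at which 3 of the 4 values shown sit.

Going by these compounds, whether the amino group changes anything on the core of compound 3 stays open.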